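Phenethyl ester in place of ethyl on a dihydropyridine-like core

A few compounds are considered here, and "the series" means these few. Any claim that something is new, unique, unknown or untested is made for them only; others in the source may bear on it.

Compound 2 `CCOC(=O)C1=C(C)NC(C)=C(C(=O)OC)C1c1[nH]cnc1Cl`: 661 nM
Compound 1 `CC1=C(C(=O)OC2CCCC2)C(c2[nH]cnc2Cl)C(C(=O)OC2CCCC2)=C(C)N1`: 97.7 nM

In an assay on isolated protein for inhibition of Voltage-dependent L-type calcium channel subunit alpha-1C (Cavia porcellus) (on this read-out lower numbers stand for stronger inhibition and higher numbers for weaker inhibition), compound 2 gives 661 nM, the higher of the two numbers, while compound 1 gives 97.7 nM, a gap beyond the usual scatter. Compound 3 `COC(=O)C1=C(C)NC(C)=C(C(=O)OCCc2ccccc2)C1c1[nH]cnc1Cl` differs from compound 2 by phenyl in place of hydrogen on a saturated chain carbon, two bonds along the chain from an oxygen next to a carbonyl group. Within the data shown here, no measured pair shows this exact change, so its effect is open. A larger ester group is expected to lower the number, because compound 1 with its bulkier esters gives 97.7 nM. The step from compound 2 to compound 3 is estimated at a 3.7-fold lower number from compound 2 to compound 3 (0.56 log units; beyond the scatter). Compound 3 is therefore expected near 180 nM, within 50 nM to 600 nM.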

Compound 3, half-maximal inhibitory concentration: 79.4 nM
Compound 3: middle estimate off by 2.3-fold (0.36 log units), on the high side; measured number inside the range.
By their numbers in this assay, from the lowest: compounds 3 and 1 (each within the scatter of the next); then compound 2.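

In this assay the change from ethyl to phenethyl gives an 8.3-fold lower number from compound 2 to compound 3 (0.92 log units; beyond the scatter) with only this ester changed. This shows that adding one phenyl ring at this position lowers the number by more than the usual scatter, which compound 1 and compound 2 could not show, since they differ in more than one place. No measurement here accounts for the step. Going by these compounds, whether a benzyl ester, a longer chain ending in phenyl, or an amine on the chain would lower the number as far remains open.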